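A few compounds are considered here, and "the series" means these few. Any claim that something is new, unique, unknown or untested is made for them only; others in the source may bear on it.

Measured so far: compound 3 `Cc1[nH]c2ccccc2c1C1=C(Br)C(=O)C(Br)=C(c2c(C)[nH]c3ccccc23)C1=O` gives 4.76 ug/mL in a functional assay on MDA-MB-231 cells (Homo sapiens) for antiproliferative activity, read by CCK-8 assay, with a stated time of 48 h; on this read-out lower numbers stand for stronger inhibition and higher numbers for weaker inhibition; compound 1 `Cc1ccc(-c2[nH]c3ccccc3c2C2=C(Br)C(=O)C(c3c(C)[nH]c4ccccc34)=C(Br)C2=O)cc1` gives 6.67 ug/mL; compound 2 `COc1ccc2[nH]c(C)c(C3=C(Br)C(=O)C(c4c(-c5ccc(C)cc5)[nH]c5ccccc45)=C(Br)C3=O)c2c1` gives 3.99 ug/mL. Compound 3 stands second highest of the three numbers, with compound 2 nearest and compound 1 furthest, both within the scatter. Among the compounds with values here, the only measured step, a 1.7-fold lower number from compound 1 to compound 2 (0.22 log units; within the scatter), concerns a methoxy group and does not bear on the change at hand. Compound 4 `Cc1[nH]c2ccccc2c1C1=C(Br)C(=O)C(Br)=C(c2c(-c3ccccc3)[nH]c3ccccc23)C1=O` differs from compound 3 by phenyl in place of methyl on an aromatic carbon. Within the data shown here, no measured step covers this change; compound 1, which carries a tolyl group where compound 3 carries methyl, gives a number within the scatter of compound 3. Compound 4 is therefore expected to show no step beyond the scatter, a 1.2-fold higher number from compound 3 to compound 4 (0.06 log units; within the scatter), with an estimated 5.5 ug/mL between 2.5 ug/mL and 12 ug/mL.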

Compound 4, half-maximal inhibitory concentration: 4.33 ug/mL
The estimate for compound 4 lay 1.3-fold (0.10 log units) above the measured number; the range from low to high includes it.
By their numbers in this assay, from the lowest: compounds 2, 4, 3 and 1 (each within the scatter of the next).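

Placing phenyl in place of methyl on this aromatic carbon, next to the ring nitrogen, produces only a small step (a 1.1-fold lower number from compound 3 to compound 4 (0.04 log units; within the scatter)), which lies within the scatter. This direct pair therefore shows that, with the rest of the structure held fixed, this position takes the larger aromatic ring without a measurable change in the number. Nothing available explains this result. The compounds shown leave open whether an amine or a carboxylic acid on the phenyl, or a longer alkyl chain in its place, would produce a step beyond the scatter.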